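Nitro for methyl: cytotoxicity notes on compounds 1 to 4

The source may report more compounds than this note shows. Statements on the series, on what has been measured and on what is new or still open speak of the compounds shown alone.

Compound 1 `Cc1nc(-c2cccnc2)sc1-c1nnc(-c2ccc([N+](=O)[O-])cc2)o1`, compound 2 `Cc1ccc(-c2nnc(-c3sc(-c4cccnc4)nc3C)o2)cc1` and compound 3 `Cc1ccccc1-c1nnc(-c2sc(-c3cccnc3)nc2C)o1` share one core and differ only in the substitution of the six-membered aromatic ring of carbon only. In an ADME assay on PANC-1 cells (Homo sapiens) for cytotoxicity, read by MTT assay (a lower number here means that less compound is tolerated, a higher number that more compound is tolerated), compound 1 gives > 100 ug/mL, which is a limit of the assay and not a number. In this assay compound 2 gives > 100 ug/mL, again a limit. In this assay compound 3 gives > 100 ug/mL, also a limit.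

The change from compound 2 to compound 1 is nitro in place of methyl on an aromatic carbon, and its step is a step that the two limits leave unreadable from compound 2 to compound 1. The change from compound 2 to compound 3 is 2-methylphenyl in place of 4-methylphenyl on an aromatic carbon, with the step that the two limits leave unreadable from compound 2 to compound 3. Neither step can be sized because the limit of > 100 ug/mL in this assay, at which 3 of the 3 values shown sit, holds every measured value in this set.

Compound 4 `Cc1nc(-c2cccnc2)sc1-c1nnc(-c2ccccc2[N+](=O)[O-])o1` is not yet measured. It differs from compound 3 by nitro in place of methyl on an aromatic carbon. This is the same kind of change as from compound 2 to compound 1, but not the same: there the nitro sits para to a large group, whereas in compound 4 it sits ortho to a large group. The expected step that the limit leaves unreadable from compound 3 to compound 4 in this assay rests on compound 3 sitting at a limit and on the step that the two limits leave unreadable from compound 2 to compound 1 being itself unreadable, so no movement can be read from the series. Compound 4 is estimated at 120 ug/mL in this assay, within a range from 50 ug/mL to 300 ug/mL, and the assay is expected most likely to return only a limit once more.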

Compound 4, half-maximal cytotoxic concentration: > 100 ug/mL
Compound 4 gave a limit, no number; the forecaster's own chance of this, stated with the estimate: 80%; the middle value is on the limit's open side.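

In this assay compound 4 gives > 100 ug/mL, a limit of the assay and not a number. No step from compound 3 to compound 4 can be read, because the whole set rests on one limit: the limit of > 100 ug/mL in this assay, at which 4 of the 4 values shown sit.

The compounds shown leave open whether nitro in place of methyl on an aromatic carbon changes cytotoxicity at all, and what actual number compound 1, compound 2, compound 3 or compound 4 would return.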